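Swapping an aromatic ring for a non-aromatic one on the sulfur-linked chain

The compounds below may be only part of what the source reports. "The series", "measured", "known", "first", "only" and "open" are said of these compounds alone.

Of the compounds shown here, three sharing one core have been measured in an assay on CHO cells for displacement of a labelled ligand from adenosine receptor A3 (Homo sapiens), read by scintillation counting, with a stated time of 120 min, tested at 1 uM; on this read-out lower numbers stand for less inhibition and higher numbers for more inhibition at the one concentration tested (going by the name of the read-out). Compound 1 `N#Cc1c(N)nc(SCc2ccn[nH]2)c(C#N)c1-c1ccc(OCC2CC2)cc1` gives 6% in this assay. Compound 2 `COC(=O)c1cccc(CSc2nc(N)c(C#N)c(-c3ccc(OCC4CC4)cc3)c2C#N)c1` gives 4% in this assay, and compound 3 `N#Cc1c(N)nc(SCc2cnc[nH]2)c(C#N)c1-c1ccc(OCC2CC2)cc1` gives 1% in this assay. Compound 3 sits at the low end of the three numbers, yet the distances to it are a number 5 percentage points lower from compound 1 to compound 3 (within the scatter) and a number 3 percentage points lower from compound 2 to compound 3 (within the scatter), and the remaining step is a number 2 percentage points lower from compound 1 to compound 2 (within the scatter), so none of the three compounds can be separated from the others.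

Compound 4 `N#Cc1c(N)nc(SCC2=NCCN2)c(C#N)c1-c1ccc(OCC2CC2)cc1` is the next compound and has not yet been measured in this assay. It differs from compound 3 only in this way: a group of 5 heavy atoms (3 carbon, 2 nitrogen; one five-membered non-aromatic ring with 2 hetero atoms) in place of a group of 5 heavy atoms (3 carbon, 2 nitrogen; one five-membered aromatic ring with 2 hetero atoms), on a saturated chain carbon bound to a sulfur. Within the data shown here, the steps that bear on this change are those that also swap the group on the saturated chain carbon bound to a sulfur, namely a number 5 percentage points lower from compound 1 to compound 3 (within the scatter) and a number 3 percentage points lower from compound 2 to compound 3 (within the scatter), both within the scatter. Three different groups at this place have therefore given numbers that cannot be told apart. The expectation for compound 4 is consequently a step of a number 2 percentage points higher from compound 3 to compound 4 (within the scatter), that is, nothing beyond the scatter. Compound 4 is estimated to give 3% in this assay, with a range from -5% to 12%.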

Compound 4, a percentage reported as inhibition, at one concentration (the size of the read-out at that concentration, not a potency): 6%
Compound 4: the middle estimate sits 3 percentage points below what was measured; measured number inside the range.
By their numbers in this assay, from the lowest: compounds 3, 2, 1 and 4 (each within the scatter of the next).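

In this assay, the non-aromatic five-membered ring on a saturated chain carbon bound to a sulfur cannot be told apart from any of the three aromatic groups: against the 1H-imidazol-5-yl group the result is (a number 5 percentage points higher from compound 3 to compound 4 (within the scatter)), against the 3-(methoxycarbonyl)phenyl group it is (a number 2 percentage points higher from compound 2 to compound 4 (within the scatter)), and against the 1H-pyrazol-5-yl group it is (no change at the digits printed from compound 1 to compound 4 (within the scatter)). The earlier compounds shown here covered only aromatic rings at this place, whereas this comparison shows that replacing the aromatic five-membered ring with a non-aromatic one, which has one double bond outside aromatic rings, gives no separable difference among the four compounds. Nothing available accounts for the four numbers staying together.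

Going by these compounds, it remains open whether any other group at this place, such as an amine, a carboxylic acid or a longer chain, would move the number beyond the scatter. Each number also comes from a single concentration, so these compounds leave their potencies undefined, and they do not show whether a change elsewhere on the shared core would make this position matter.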